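The source may report more compounds than this note shows. Statements on the series, on what has been measured and on what is new or still open speak of the compounds shown alone.

Measured compounds:
compound 1, `CS(=O)(=O)c1ccc(Cc2nnc3n2N=C(c2ccccc2)CS3)cc1`: 42%
compound 2, `CS(=O)(=O)c1ccc(Cc2nnc3n2N=C(c2ccc(-c4ccccc4)cc2)CS3)cc1`: 58.2%

Among the compounds with values here, in a functional assay on HT-29 cells (Homo sapiens) for cytotoxicity, read by MTT assay, with a stated time of 48 h, tested at 12.5 uM (a higher number here means a stronger effect of the compound at the concentration tested, a lower number a weaker effect), compound 1 gives 42%, the lower of the two numbers known so far. Compound 2 gives 58.2%, and the step of a number 16.2 percentage points higher from compound 1 to compound 2 (beyond the scatter) came with a phenyl in place of hydrogen on an aromatic carbon. Compound 3, `CS(=O)(=O)c1ccc(Cc2nnc3n2N=C(c2cc(Cl)sc2S(N)(=O)=O)CS3)cc1`, has not yet been tested. Its difference from compound 1 is of another kind: 5-chloro-2-sulfamoylthiophen-3-yl in place of phenyl on a carbon with a double bond to nitrogen. Within the data shown here, no measured step involves this exchange. Among the measured compounds shown here, the one known step, a number 16.2 percentage points higher from compound 1 to compound 2 (beyond the scatter), concerns adding a phenyl to an aromatic carbon rather than replacing the whole phenyl with a chlorinated, sulfamoyl-bearing thiophene, so it offers no direct guide, and nothing in the data points to a change in either direction. The expectation for compound 3 is therefore a number close to that of compound 1, with a step of a number 3 percentage points higher from compound 1 to compound 3 (within the scatter) that is expected to stay within the scatter. The estimate for compound 3 in this assay is 45%, with a range from 25% to 65%.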

Compound 3, a percentage reported as activity, at one concentration (the size of the read-out at that concentration, not a potency): 22.8%
Beside the measured number, compound 3's estimate is 22.2 percentage points above it; measured number below the stated range.
By their numbers in this assay, from the lowest: compound 3; then compound 1; then compound 2.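

In this assay, the place held by the phenyl on the carbon with a double bond to nitrogen proves sensitive to a full exchange of that ring: putting 5-chloro-2-sulfamoylthiophen-3-yl there gives a number 19.2 percentage points lower from compound 1 to compound 3 (beyond the scatter), a change in the opposite direction to the one seen so far. That earlier step, a number 16.2 percentage points higher from compound 1 to compound 2 (beyond the scatter), came with phenyl in place of hydrogen on an aromatic carbon, so changes to this part of the molecule, with the rest of the structure held constant, can move the number either way. Nothing available explains why the thiophene exchange goes with the lower number.

The exchange alters the ring and brings in both a chlorine and a sulfamoyl group at once, so the compounds shown leave open which of these parts goes with the drop. An unsubstituted thiophen-3-yl, a 5-chlorothiophen-3-yl or a phenyl carrying a single sulfamoyl group in this place would help to separate those parts, and an amine or a carboxylic acid on the ring would test how far the trend extends.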